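A methoxy on the distal ring of compound 3

This account rests on a few compounds, and the source may have more. Where it says the series, first, only, none or still open, it means among the compounds named here.

Compound 3 `CCCCCCCCS(=O)(=O)Nc1ccc(CCc2ccccc2)cc1C(=O)O` carries the shared core with a phenethyl group, and in an assay on mitochondria (strain BALB/c) for inhibition of glycerol-3-phosphate acyltransferase 1, mitochondrial (Mus musculus), read by scintillation counting, with a stated time of 10 min (on this read-out lower numbers stand for stronger inhibition and higher numbers for weaker inhibition), compound 3 gives 37500 nM. Among the three measured compounds it holds the second highest number. Its nearest neighbour is compound 1 `CCCCCCCCS(=O)(=O)Nc1ccc(-c2ccccc2F)cc1C(=O)O`, which gives 34600 nM; a 1.1-fold higher number from compound 1 to compound 3 (0.03 log units; within the scatter). Compound 2 `CCCCCCCCS(=O)(=O)Nc1ccc(C(=O)c2ccccc2OC)cc1C(=O)O` gives 59200 nM, and a 1.6-fold lower number from compound 2 to compound 3 (0.20 log units; within the scatter). The remaining step is likewise small: a 1.7-fold higher number from compound 1 to compound 2 (0.23 log units; within the scatter). All three measured compounds therefore sit together on this read-out.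

Compound 4 `CCCCCCCCS(=O)(=O)Nc1ccc(CCc2ccc(OC)cc2)cc1C(=O)O` differs from compound 3 in one place: methoxy in place of hydrogen on an aromatic carbon. Going by the values given here, no measured step adds a methoxy to an otherwise unchanged structure; compound 2 does carry a methoxy, but inside a larger group exchange, so its step to compound 3 does not isolate the effect of that group alone. With every measured step within the scatter, compound 4 is expected to stay close to compound 3. The expected step is a 1.1-fold higher number from compound 3 to compound 4 (0.03 log units; within the scatter). The estimate for compound 4 is 40000 nM, with a range from 15000 nM to 110000 nM.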

Compound 4, half-maximal inhibitory concentration: 26300 nM
The estimate for compound 4 lay 1.5-fold (0.18 log units) above the measured number; the range from low to high includes it.
By their numbers in this assay, from the lowest: compounds 4, 1, 3 and 2 (each within the scatter of the next, the first and the last beyond it).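

Methoxy in place of hydrogen on an aromatic carbon, para to a large group, is the first change in the series that adds one group to an otherwise unchanged structure, and in this assay it gives a 1.4-fold lower number from compound 3 to compound 4 (0.15 log units; within the scatter), which leaves this position's effect within the scatter. The exchange of 2-fluorophenyl for 2-(4-methoxyphenyl)ethyl likewise stays within it, with a 1.3-fold lower number from compound 1 to compound 4 (0.12 log units; within the scatter). Going by these compounds alone, only the exchange of (2-methoxyphenyl)carbonyl for 2-(4-methoxyphenyl)ethyl goes beyond the scatter, and only modestly, with a 2.3-fold lower number from compound 2 to compound 4 (0.35 log units; beyond the scatter), the first step to do so.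

Nothing available accounts for these steps. The compounds shown leave open whether an amine or a carboxylic acid in place of the methoxy would move the number further than the methoxy does.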